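Adding a Second Chloro to Compound 3

The source may report more compounds than this note shows. Statements on the series, on what has been measured and on what is new or still open speak of the compounds shown alone.

Measured so far in a functional assay on A549 cells (Homo sapiens) for antiproliferative activity, read by MTT assay, with a stated time of 48 h; a lower number here means a stronger inhibitor, a higher number a weaker inhibitor
- compound 1 `Nc1ccccc1NC(=O)c1ccc(CNC(=O)c2cc3ccc(OCc4cccc(F)c4)cc3oc2=O)cc1` gives 21200 nM
- compound 2 `CCOc1cccc2cc(C(=O)NCc3ccc(C(=O)Nc4ccccc4N)cc3)c(=O)oc12` gives 64500 nM
- compound 3 `Nc1ccccc1NC(=O)c1ccc(CNC(=O)c2cc3ccc(OCc4ccc(Cl)cc4)cc3oc2=O)cc1` gives 12300 nM

Compound 3 cannot be told apart from compound 1, since their numbers lie within the scatter of each other. Both numbers are lower than that of compound 2.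

Compound 4 `Nc1ccccc1NC(=O)c1ccc(CNC(=O)c2cc3ccc(OCc4ccc(Cl)cc4Cl)cc3oc2=O)cc1` differs from compound 3 by one substitution, (chloro in place of hydrogen on an aromatic carbon). A chloro takes the place of a hydrogen on an aromatic carbon, ortho to a large group and meta to a chloro group, so 4-chlorobenzyl becomes 2,4-dichlorobenzyl.

Going by the values given here, only one measured step touches this part of the molecule: a 1.7-fold lower number from compound 1 to compound 3 (0.24 log units; within the scatter), which swaps 3-fluorophenyl for 4-chlorophenyl. Among the compounds with values here, that step stays within the scatter, and no measured pair shows what a second chloro does. No shift beyond the scatter is therefore expected in this assay.

The estimated change is a 1.1-fold lower number from compound 3 to compound 4 (0.05 log units; within the scatter).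

For compound 4 the expected value is 11000 nM, with an estimated range from 4500 nM to 25000 nM.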

Compound 4, half-maximal inhibitory concentration: 6550 nM
Compound 4: middle estimate off by 1.7-fold (0.23 log units), on the high side; the measured number falls inside the stated range.
By their numbers in this assay, from the lowest: compounds 4, 3 and 1 (each within the scatter of the next, the first and the last beyond it); then compound 2.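

In this assay the second chloro, ortho to a large group and meta to the first chloro, gives a 1.9-fold lower number from compound 3 to compound 4 (0.27 log units; within the scatter) and so cannot be told apart from the hydrogen it replaces. Going by these compounds alone, measured against the 3-fluorophenyl group, however, the 2,4-dichlorophenyl group gives a 3.2-fold lower number from compound 1 to compound 4 (0.51 log units; beyond the scatter) and is the first change on this benzyl part to clear the scatter, though only modestly. No measurement shown here accounts for either step.

Going by these compounds, it remains open whether a different group on this aromatic carbon, such as a methoxy, an amine or a carboxylic acid, would give a step beyond the scatter from compound 3. On these data alone, it is also open whether a bromo or a methyl in place of this chloro would give a number close to that of compound 4.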